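Methoxy in Place of Methyl on the Urea Aryl Ring

The source may hold more compounds than are shown below. What is called first, only, known or untested is meant among the compounds shown, and "the series" means these compounds.

Compound 1 `CCN(CC)Cc1ccc(NC(=O)Nc2ccc3ncnc(Nc4cccc(C(F)(F)F)c4)c3c2)cc1` gives 3980 nM in a functional assay on A-431 cells (Homo sapiens) for antiproliferative activity, read by MTT assay, with a stated time of 72 h; a lower number here means a stronger inhibitor, a higher number a weaker inhibitor.
Compound 2 `O=C(Nc1ccccc1)Nc1ccc2ncnc(Nc3cccc(C(F)(F)F)c3)c2c1` gives only a limit of the method in this assay, > 10000 nM.
Compound 3 `Cc1ccc(NC(=O)Nc2ccc3ncnc(Nc4cccc(C(F)(F)F)c4)c3c2)cc1` gives only a limit of the method in this assay, > 10000 nM.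

Compound 3 thus stands at the limit (the limit of > 10000 nM in this assay, at which 2 of the 3 values shown sit), where compound 2 also sits; compound 1 alone has a number. Both measured steps away from compound 1 run the same way: an at least 2.5-fold higher number from compound 1 to compound 2 (0.40 log units; beyond the scatter) and an at least 2.5-fold higher number from compound 1 to compound 3 (0.40 log units; beyond the scatter). Between compound 2 and compound 3 the two limits leave the step unreadable: a step that the two limits leave unreadable from compound 2 to compound 3.

Compound 4 `COc1ccc(NC(=O)Nc2ccc3ncnc(Nc4cccc(C(F)(F)F)c4)c3c2)cc1` differs from compound 3 by methoxy in place of methyl on an aromatic carbon. No measured step alters a group on this ring in a comparable way, so nothing shown bears directly on the change. Compound 4 is therefore expected to stay close to compound 3, with a step that the limit leaves unreadable from compound 3 to compound 4 expected within the scatter. The estimate for compound 4 is 12000 nM, in a range from 5000 nM to 30000 nM, most probably reported again as a limit.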

Compound 4, half-maximal inhibitory concentration: 4950 nM
Estimate against measurement, compound 4: 2.4-fold (0.38 log units) above; the measured number lies below the stated range.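

Methoxy at this place gives a readable number without any diethylamino group, with an at least 2.0-fold lower number from compound 3 to compound 4 (0.30 log units; that floor lies within the scatter) and an at least 2.0-fold lower number from compound 2 to compound 4 (0.30 log units; that floor lies within the scatter). Both steps are only floors because compounds 2 and 3 sit at a limit: the limit of > 10000 nM in this assay, at which 2 of the 4 values shown sit. Compound 4 stands level with the (diethylamino)methyl compound, with a 1.2-fold higher number from compound 1 to compound 4 (0.09 log units; within the scatter).

The true size of the steps from the two limit compounds stays unread. The compounds shown also leave open whether ethoxy, hydroxyl or fluorine at this place would give a readable number too.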